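The compounds below may be only part of what the source reports. "The series", "measured", "known", "first", "only" and "open" are said of these compounds alone.

Measured compounds: in an assay on RBL-1 cells for inhibition of Polyunsaturated fatty acid 5-lipoxygenase (Rattus norvegicus) (on this read-out higher numbers stand for weaker inhibition and lower numbers for stronger inhibition), compound 1 `O=C1NCCN(c2cccc(F)c2)N1` gives 19000 nM, compound 2 `O=C1NCCN(c2cccc(OCc3ccccc3)c2)N1` gives 1100 nM, and compound 3 `CC1CN(c2cccc(F)c2)NC(=O)N1` gives 6300 nM.

For the measured compounds named here, compound 3 stands second highest of the three numbers; the single recorded step, a 3.0-fold lower number from compound 1 to compound 3 (0.48 log units; beyond the scatter), is modest. Compound 4 `CC1CN(c2cccc(-c3cccs3)c2)NC(=O)N1` differs from compound 3 by thiophen-2-yl in place of fluoro on an aromatic carbon. Going by the values given here, no measured step covers this kind of exchange. Among the compounds with values here, the only pointer is the pair compound 1 and compound 2, where a larger group in place of fluoro on the aromatic ring goes with a markedly lower number in this assay. On that basis compound 4 is expected to move down, roughly a 4.8-fold lower number from compound 3 to compound 4 (0.69 log units; beyond the scatter), though the guide is indirect. The estimate for compound 4 is 1300 nM, with a range of 300 nM to 5000 nM.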

Compound 4, half-maximal inhibitory concentration: 2800 nM
Beside the measured number, compound 4's estimate is 2.2-fold (0.33 log units) below it, within the range that was stated.
By their numbers in this assay, from the lowest: compound 2; then compound 4; then compound 3; then compound 1.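

At the aromatic carbon that carries fluoro, thiophen-2-yl in place of fluoro gives a 2.3-fold lower number from compound 3 to compound 4 (0.35 log units; beyond the scatter) in this assay and so a modest gain on the core that keeps the methyl on the saturated ring carbon. A five-membered aromatic ring with a sulfur atom is therefore tolerated at this position, with no loss on this read-out. No measurement at hand bears on what lies behind this step.

On these data alone, whether phenyl, an amine or a carboxylic acid at this aromatic carbon would match thiophen-2-yl stays open. Also open, as far as these compounds go, is how the benzyloxy group of compound 2 would behave with the methyl present.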